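From quinolin-5-yl to 1-(methoxycarbonyl)piperidin-4-yl

The source may hold more compounds than are shown below. What is called first, only, known or untested is meant among the compounds shown, and "the series" means these compounds.

In a physicochemical assay for solubility, in phosphate buffer, at pH 7.4 (on this read-out higher numbers stand for higher solubility and lower numbers for lower solubility), compound 1 `N#CC1CCN(c2nccnc2OC2CN(c3ccc4ccccc4n3)C2)CC1` gives 66000 nM and compound 2 `c1ccc2nc(N3CC(Oc4nccnc4-c4cccc5ncccc45)C3)ccc2c1` gives 47000 nM. Among the measured compounds shown here, these two numbers lie within the scatter of each other, so compound 2 stands level with the only other measured compound.

Compound 3 `COC(=O)N1CCC(c2nccnc2OC2CN(c3ccc4ccccc4n3)C2)CC1` changes one group on the shared core: 1-(methoxycarbonyl)piperidin-4-yl in place of quinolin-5-yl on an aromatic carbon. Here 1-(methoxycarbonyl)piperidin-4-yl takes the place of quinolin-5-yl on an aromatic carbon, next to the ring nitrogen.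

For the measured compounds named here, only one measured step bears on this change: a 1.4-fold lower number from compound 1 to compound 2 (0.15 log units; within the scatter). In that step, quinolin-5-yl replaced 4-cyanopiperidin-1-yl on an aromatic carbon, and the difference stayed within the scatter. A single step shows no trend, so no step beyond the scatter is expected in this assay, in either direction.

The expected outcome is a 1.1-fold higher number from compound 2 to compound 3 (0.03 log units; within the scatter). For compound 3 the estimated value is 50000 nM, with an expected range from 20000 nM to 110000 nM.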

Compound 3, solubility: 138000 nM
For compound 3 the middle estimate is 2.8-fold (0.44 log units) below the measured one; measured number outside the range, above it.
By their numbers in this assay, from the lowest: compounds 2 and 1 (each within the scatter of the next); then compound 3.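

In this assay, this position now shows a change beyond the scatter: putting 1-(methoxycarbonyl)piperidin-4-yl in place of quinolin-5-yl on the aromatic carbon gives a 2.9-fold higher number from compound 2 to compound 3 (0.47 log units; beyond the scatter). The same group in place of 4-cyanopiperidin-1-yl also gives a change beyond the scatter, a 2.1-fold higher number from compound 1 to compound 3 (0.32 log units; beyond the scatter), so the position, which looked flat with only compound 1 and compound 2 in hand, does respond to the group placed on it. Nothing available here gives a reason for this rise.

Going by these compounds, it stays open whether the rise goes with the methoxycarbonyl part or with the ring that carries it. Also open, on these data alone, is how a free amine, such as piperidin-4-yl without the methoxycarbonyl, or a carboxylic acid on this carbon would read in this assay.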